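Furan regiochemistry at the aryl position: compound 4

The source may hold more compounds than are shown below. What is called first, only, known or untested is meant among the compounds shown, and "the series" means these compounds.

Compound 2 `Cc1nc(N)c2c(-c3ccco3)cn([C@@H]3O[C@H](CO)[C@@H](O)[C@H]3O)c2n1` stands only at a limit in a functional assay on CEM-DNR-bulk cells (Homo sapiens), read by MTT assay, with a stated time of 72 h; on this read-out higher numbers stand for weaker inhibition and lower numbers for stronger inhibition. In this assay compound 2 gives > 20000 nM, a limit of the assay rather than a number. Compound 1 `Cc1nc(N)c2c(-c3ccccc3)cn([C@@H]3O[C@H](CO)[C@@H](O)[C@H]3O)c2n1` sits at the same limit; in this assay compound 1 gives > 20000 nM. Compound 3 `COc1nc(N)nc2c1c(-c1cccs1)cn2[C@@H]1O[C@H](CO)[C@@H](O)[C@H]1O` does too; in this assay compound 3 gives > 20000 nM. All three rest on (the limit of > 20000 nM in this assay, at which 3 of the 3 values shown sit). Compound 4 `Cc1nc(N)c2c(-c3ccoc3)cn([C@@H]3O[C@H](CO)[C@@H](O)[C@H]3O)c2n1` differs from compound 2 by furan-3-yl in place of furan-2-yl on an aromatic carbon. For the measured compounds named here, the only measured step touching compound 2, a step that the two limits leave unreadable from compound 1 to compound 2, has no readable size, so no measured step gives a usable magnitude for this change. Compound 4 is expected to give 30000 nM, within 10000 nM to 100000 nM, most likely again as a limit. The step is estimated at a step that the limit leaves unreadable from compound 2 to compound 4, with no change expected beyond the scatter.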

Compound 4, half-maximal inhibitory concentration: > 20000 nM
Compound 4 gave a limit, no number (the forecaster's own chance of this, stated with the estimate: 85%); the middle value lies beyond the limit too.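

No step can be read between compound 4 and compound 1 or compound 2 in this assay, as all three values are limits. The compounds shown leave open how phenyl, furan-2-yl and furan-3-yl rank against one another, with every value resting on one limit: the limit of > 20000 nM in this assay, at which 4 of the 4 values shown sit.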